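The compounds below may be only part of what the source reports. "The series", "measured", "known", "first", "only" and "open" are said of these compounds alone.

Measured in a physicochemical assay for lipophilicity, at pH 7.4; a higher number here means a more lipophilic compound, a lower number a more polar compound:
Compound 1 `Cc1cc(C)c(CN2CCc3ccc(O[C@@H]4CCOC4)c(Cl)c3C2=O)c(=O)[nH]1`: 1.5
Compound 2 `Cc1cc(C)c(CN2CCc3ccc(OC(C)C)cc3C2=O)c(=O)[nH]1`: 2.5
Compound 3 `Cc1cc(C)c(CN2CCc3ccc(-c4c(C)noc4C)c(Cl)c3C2=O)c(=O)[nH]1`: 2.6

In this assay compound 3, at 2.6, lies within the scatter of compound 2 and beyond the scatter of compound 1. Compound 4 `Cc1cc(C)c(CN2CCc3ccc(OC(C)C)c(Cl)c3C2=O)c(=O)[nH]1` follows, with isopropoxy in place of 3,5-dimethyl-1,2-oxazol-4-yl on an aromatic carbon: isopropoxy in place of 3,5-dimethyl-1,2-oxazol-4-yl, ortho to a chloro group. For the measured compounds named here, one measured step bears on this change: a number 1.10 log units higher from compound 1 to compound 3 (beyond the scatter), a large one, in which (oxolan-3-yl)oxy gives way to that same 3,5-dimethyl-1,2-oxazol-4-yl. Compound 2, which carries isopropoxy but no chloro group, gives 2.5, so only a small change is expected here. The expected step is a number 0.20 log units higher from compound 3 to compound 4 (within the scatter). For compound 4 the estimated value is 2.8, with an expected range of 2.4 to 3.2.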

Compound 4, distribution coefficient: 2.7
Estimate against measurement, compound 4: 0.10 log units above; measured number inside the range.
By their numbers in this assay, from the lowest: compound 1; then compounds 2, 3 and 4 (each within the scatter of the next).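

In this assay, isopropoxy ortho to a chloro group matches 3,5-dimethyl-1,2-oxazol-4-yl, giving a number 0.10 log units higher from compound 3 to compound 4 (within the scatter) and leaving the large difference with the (oxolan-3-yl)oxy group, which now reads as a number 1.20 log units higher from compound 1 to compound 4 (beyond the scatter) when isopropyl replaces oxolan-3-yl on the same oxygen. Chloro in place of hydrogen, read directly for the first time, gives a number 0.20 log units higher from compound 2 to compound 4 (within the scatter) with isopropoxy in place. No evidence on the reason for these numbers is at hand. From the compounds shown here alone, whether an amine, a carboxylic acid or a longer chain on the oxygen would stay level with isopropoxy here remains open.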